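Chain lengthening and cytotoxicity in one alkynyl series

The source may report more compounds than this note shows. Statements on the series, on what has been measured and on what is new or still open speak of the compounds shown alone.

The three measured compounds share one core and differ only in the saturated chain on the triple bond. Compound 1 is `CCCCCCCC#Cc1cc2cn(COCCO)c(=O)nc2o1`; in a functional assay on HEL cells (Homo sapiens), read by microscopy (on this read-out lower numbers stand for higher toxicity in this test and higher numbers for lower toxicity in this test), compound 1 gives 200000 nM. Compound 2 is `CCCCCCCCC#Cc1cc2cn(COCCO)c(=O)nc2o1`. For compound 2 only a limit is known in this assay, >= 20000 nM. Compound 3 is `CCCCC#Cc1cc2cn(COCCO)c(=O)nc2o1`. For compound 3 too only a limit is known in this assay, > 100000 nM. Among the compounds with values here, compound 3 therefore stands at a limit, not at a number, and of the three values shown only that of compound 1 is a number.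

The steps that connect the measured compounds cannot be sized: a step that the limit leaves unreadable from compound 1 to compound 3, a step that the two limits leave unreadable from compound 2 to compound 3 and a step that the limit leaves unreadable from compound 1 to compound 2 all stay unreadable, which follows from the limit of > 100000 nM in this assay, at which 1 of the 3 values shown sits, and from the limit of >= 20000 nM in this assay, at which 1 of the 3 values shown sits.

Compound 4 is `CCCCCCCCCC#Cc1cc2cn(COCCO)c(=O)nc2o1`. It differs from compound 3 by pentyl in place of hydrogen on a saturated chain carbon, four bonds along the chain from a triple-bonded carbon. Within the data shown here, the steps from compound 3 to compound 1 and to compound 2 are the same kind of change, hydrogen replaced by a chain at that carbon, and both stay unreadable, so no direction for the step in this assay can be drawn from them. Compound 4 is expected to give about 100000 nM, within 20000 nM to 400000 nM, most likely as another limit. The step of a number no higher from compound 3 to compound 4 (the limit leaves the size open) is thus expected to be no more than an unreadable shift between limits.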

Compound 4, minimum cytotoxic concentration: >= 20000 nM
Compound 4: only a limit was reported; the forecaster's own chance of this, stated with the estimate: 60%; the middle value does not contradict the limit.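

In this assay compound 4 gives >= 20000 nM as a limit and not a number, so its steps to compound 1, compound 2 and compound 3 cannot be read. The compounds shown leave open whether the length of the saturated chain on the triple bond changes the result in this assay at all, and in which direction.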